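Ring Swap at the Chain End: Predicting Compound 4

This account rests on a few compounds, and the source may have more. Where it says the series, first, only, none or still open, it means among the compounds named here.

Compound 1 `O=C(/C=C/c1ccoc1)c1cc(O)c(O)c([N+](=O)[O-])c1`: in an assay for inhibition of Catechol O-methyltransferase (Rattus norvegicus), read by fluorescence and spectrophotometry (a higher number here means a weaker inhibitor, a lower number a stronger inhibitor), compound 1 gives 290 nM.
Compound 2 `O=C(/C=C/c1cccc(O)c1)c1cc(O)c(O)c([N+](=O)[O-])c1`: compound 2 gives 140 nM.
Compound 3 `O=C(/C=C/c1cccs1)c1cc(O)c(O)c([N+](=O)[O-])c1`: compound 3 gives 190 nM.

Among the three measured compounds, compound 3 stands second highest. Its nearest neighbour is compound 2, and compound 1 is furthest from it, yet both gaps fall within the usual scatter of this assay, so no order among them can be read with confidence.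

Compound 4 `Cn1cc(/C=C/C(=O)c2cc(O)c(O)c([N+](=O)[O-])c2)cn1` is the next member of the series. Among the compounds with values here, its single difference from compound 3 is 1-methyl-1H-pyrazol-4-yl in place of thiophen-2-yl on a double-bonded chain carbon bound to a double-bonded chain carbon.

Three earlier steps bear on this exchange, each altering the same ring at the same place. The step of a 1.5-fold lower number from compound 1 to compound 3 (0.18 log units; within the scatter) and the step of a 1.4-fold higher number from compound 2 to compound 3 (0.13 log units; within the scatter) both stayed within the scatter, while a 2.1-fold lower number from compound 1 to compound 2 (0.32 log units; beyond the scatter) was only modest. Exchanging one small aromatic ring for another at this position has therefore moved the number little so far.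

For compound 4 a step of about a 1.2-fold higher number from compound 3 to compound 4 (0.08 log units; within the scatter) is expected, not clearly beyond the scatter. The estimated value for compound 4 is 230 nM, with a likely range from 110 nM to 480 nM.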

Compound 4, half-maximal inhibitory concentration: 290 nM
Estimate against measurement, compound 4: 1.3-fold (0.10 log units) below, within the range that was stated.
By their numbers in this assay, from the lowest: compounds 2, 3, 1 and 4 (each within the scatter of the next, the first and the last beyond it).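

In this assay, the 1-methyl-1H-pyrazol-4-yl ring, with 2 hetero atoms and 2 hydrogen-bond acceptors, gives a 1.5-fold higher number from compound 3 to compound 4 (0.18 log units; within the scatter) and no change at the digits printed from compound 1 to compound 4 (within the scatter), so this place also accepts this ring without a step beyond the scatter from either of those five-membered rings. Within the data shown here, the only step beyond the scatter is a modest one, a 2.1-fold higher number from compound 2 to compound 4 (0.32 log units; beyond the scatter), yet no clean split of five-membered rings from 3-hydroxyphenyl follows, since compound 3 goes against it with a 1.4-fold higher number from compound 2 to compound 3 (0.13 log units; within the scatter). No measurement shown here explains these differences.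

Every group shown at this place is an aromatic ring, so it stays open how an amine, a carboxylic acid or a longer chain on the double-bonded chain carbon would behave. From the compounds shown here alone, it also stays open what the methyl on the ring of compound 4 contributes.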